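Chain extension toward the isothiocyanate: a repeated change

The source may hold more compounds than are shown below. What is called first, only, known or untested is meant among the compounds shown, and "the series" means these compounds.

Compound 1 `[O-][S+](CCCCN=C=S)Cc1ccccc1`, compound 2 `[O-][S+](CCCCCN=C=S)Cc1ccccc1` and compound 3 `CC(C)[S+]([O-])CCCCCN=C=S` have been measured; compound 4 `CC(C)[S+]([O-])CCCCCCN=C=S` has not. In a functional assay on A549 cells (Homo sapiens) for cytotoxicity, read by MTT assay, with a stated time of 72 h (on this read-out lower numbers stand for stronger inhibition and higher numbers for weaker inhibition), compound 1 gives 7410 nM, compound 2 gives 6210 nM and compound 3 gives 7750 nM. The change a group of 4 heavy atoms (2 carbon, 1 nitrogen, 1 sulfur; no ring) in place of a group of 3 heavy atoms (1 carbon, 1 nitrogen, 1 sulfur; no ring), on a saturated chain carbon, four bonds along the chain from a sulfur produced a 1.2-fold lower number from compound 1 to compound 2 (0.08 log units; within the scatter). The difference between the core of compound 1 and the core of compound 3 is not broken down here. Compound 4 differs from compound 3 by a group of 4 heavy atoms (2 carbon, 1 nitrogen, 1 sulfur; no ring) in place of a group of 3 heavy atoms (1 carbon, 1 nitrogen, 1 sulfur; no ring), on a saturated chain carbon, five bonds along the chain from a sulfur; the place is five bonds along the chain from a sulfur rather than four, so this is the same kind of change, not the same one. Because a 1.2-fold lower number from compound 1 to compound 2 (0.08 log units; within the scatter) stayed within the scatter, the step from compound 3 to compound 4 is expected to be a 1.2-fold lower number from compound 3 to compound 4 (0.06 log units; within the scatter). Compound 4 is therefore estimated at 6700 nM, with a range from 3500 nM to 13000 nM.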

Compound 4, half-maximal inhibitory concentration: 12000 nM
Estimate against measurement, compound 4: 1.8-fold (0.25 log units) below; measured number inside the range.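

The same kind of change on the second core gave a 1.5-fold higher number from compound 3 to compound 4 (0.19 log units; within the scatter) in this assay. Set beside the earlier step, the two do not differ by more than repeated measurements of this kind would: the same change on two cores in this assay, a 1.2-fold lower number (0.08 log units; within the scatter) from compound 1 to compound 2 and a 1.5-fold higher number (0.19 log units; within the scatter) from compound 3 to compound 4, 1.8-fold (0.27 log units) apart, within the scatter of two such steps

So the change behaves alike on both cores as far as these two pairs can tell, but both steps are small and sit at different places on the chain, so this shows no sizeable effect being carried over and sets no rule for the series.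

The compounds shown leave open what a still longer chain would do on either core in this assay. They also leave open what an amine or a carboxylic acid in place of the isothiocyanate would do.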